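From propyl to octyl: the step to compound 3

The compounds below may be only part of what the source reports. "The series", "measured", "known", "first", "only" and "open" are said of these compounds alone.

Within the data shown here, only two compounds have numbers so far in a functional assay on MDA-MB-231 cells (Homo sapiens) for inhibition, read by MTT assay, with stated times of 18 h and 4 h; a lower number here means a stronger inhibitor, a higher number a weaker inhibitor. Compound 1 `CCCCCCCCOP(=O)(O)OCCSC(=S)N1CCCC1` gives 69000 nM, and compound 2 `CCCOP(=O)(O)OCCSC(=S)N1CCCCC1` gives 68000 nM. Among the measured compounds shown here, compound 2 therefore stands within the scatter of compound 1, the only other number at hand.

Compound 3 `CCCCCCCCOP(=O)(O)OCCSC(=S)N1CCCCC1` has not yet been measured. It differs from compound 2 in one place: pentyl in place of hydrogen on a saturated chain carbon, three bonds along the chain from an oxygen on an unsaturated carbon. Cut one bond further out, the same difference reads propyl to octyl.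

For the measured compounds named here, no measured pair differing in one place shows what such a change does. In this assay a small step towards a lower number is expected, hardly beyond the scatter. That expectation rests on compound 1 at 69000 nM and compound 2 at 68000 nM, two values that sit close together. The estimated change is a 1.4-fold lower number from compound 2 to compound 3 (0.13 log units; within the scatter). For compound 3 the expected value is 50000 nM, with an estimated range from 20000 nM to 100000 nM.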

Compound 3, half-maximal inhibitory concentration: 11900 nM
Beside the measured number, compound 3's estimate is 4.2-fold (0.62 log units) above it, and the stated range ends above it.
By their numbers in this assay, from the lowest: compound 3; then compounds 2 and 1 (each within the scatter of the next).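

In this assay, the change from propyl to octyl brings a 5.7-fold lower number from compound 2 to compound 3 (0.76 log units; beyond the scatter), so pentyl in place of hydrogen at this place on the chain does shift the number, something the two earlier values could not show. The other end of the molecule matters as well: with octyl held constant, piperidin-1-yl in place of pyrrolidin-1-yl on a thiocarbonyl carbon gives a 5.8-fold lower number from compound 1 to compound 3 (0.76 log units; beyond the scatter), a step of about the same size. Among these three compounds, only compound 3 carries both octyl and piperidin-1-yl, and it alone stands apart from the others, since each single change away from it gives a number beyond the scatter.

Nothing at hand explains why either change has this effect.

The compounds shown leave open whether the trend along the chain is gradual or continues, as butyl, hexyl or a longer chain such as dodecyl would tell. They also leave open whether the ring step depends on the chain, which the propyl compound with pyrrolidin-1-yl would test, and whether a ring such as morpholin-4-yl could take the place of piperidin-1-yl.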